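A few compounds are considered here, and "the series" means these few. Any claim that something is new, unique, unknown or untested is made for them only; others in the source may bear on it.

In a functional assay on GBM3 cells (Homo sapiens) for antiproliferative activity, read by WST assay, with a stated time of 72 h (on this read-out lower numbers stand for stronger inhibition and higher numbers for weaker inhibition), three compounds built on a shared core have been measured so far. Compound 1 `O=C(Nc1ccc(Cl)c(Cl)c1)Nc1cc2ncncc2cc1OCc1cccc(F)c1` gives 2000 nM, compound 2 `O=C(Nc1ccccc1F)Nc1cc2ncncc2cc1OCc1ccccc1F` gives 3800 nM, and compound 3 `O=C(Nc1ccccc1F)Nc1cc2ncncc2cc1OCc1cccc(Cl)c1` gives 7500 nM. Among the measured compounds shown here, the number for compound 3 lies within the usual scatter of the one for compound 2, but beyond the scatter from the lower number for compound 1.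

Compound 4 `O=C(Nc1ccccc1F)Nc1cc2ncncc2cc1OCc1cccc(F)c1` differs from compound 3 by one exchange: fluoro in place of chloro on an aromatic carbon, with fluoro in place of chloro on an aromatic carbon, meta to a large group. For the measured compounds named here, the one measured step at this part of the molecule is a 2.0-fold higher number from compound 2 to compound 3 (0.30 log units; within the scatter), with 3-chlorophenyl in place of 2-fluorophenyl. Compound 1, at 2000 nM, also carries the (3-fluorobenzyl)oxy group, but it differs elsewhere, so it offers no direct comparison. The measured step stayed within the scatter, and no step beyond the scatter is expected in this assay here. The expected change is a 1.5-fold lower number from compound 3 to compound 4 (0.18 log units; within the scatter). For compound 4 the estimated value is 5000 nM, with an expected range from 2500 nM to 10000 nM.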

Compound 4, half-maximal inhibitory concentration: 8100 nM
Beside the measured number, compound 4's estimate is 1.6-fold (0.21 log units) below it; measured number inside the range.
By their numbers in this assay, from the lowest: compounds 1, 2, 3 and 4 (each within the scatter of the next, the first and the last beyond it).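

In this assay, fluoro in place of chloro on an aromatic carbon, meta to a large group, gives a 1.1-fold higher number from compound 3 to compound 4 (0.03 log units; within the scatter), so the two groups cannot be told apart at this position. Compound 4 also shows what moving the fluoro does: 3-fluorophenyl in place of 2-fluorophenyl gives a 2.1-fold higher number from compound 2 to compound 4 (0.33 log units; beyond the scatter), a modest step just beyond the scatter. With the (3-fluorobenzyl)oxy group held fixed, 2-fluorophenyl in place of 3,4-dichlorophenyl on the amide-type nitrogen gives a 4.1-fold higher number from compound 1 to compound 4 (0.61 log units; beyond the scatter), so the number also responds to that other place.

Going by these compounds, whether a methoxy group or an amine at the same aromatic carbon would shift the number remains open. Nothing available explains why these steps have the sizes they do.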